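Fluoro for methyl: three measured compounds, one pending

The source may hold more compounds than are shown below. What is called first, only, known or untested is meant among the compounds shown, and "the series" means these compounds.

Measured so far:
Compound 1, `CC(=O)c1ccc(OCc2ccccc2C)cc1`, in an assay on isolated protein for inhibition of Amine oxidase [flavin-containing] A (Homo sapiens), read by Amplex Red, with a stated time of 15 min, tested at 100 uM (a higher number here means more inhibition at the concentration tested (going by the name of the read-out), a lower number less inhibition), gives 42.9%.
Compound 2, `CC(=O)c1ccc(OCc2cccc(C)c2)cc1`, in this assay gives 32.3%.
Compound 3, `CC(=O)c1ccc(OCc2ccccc2F)cc1`, in this assay gives 47.1%.

Compound 1 and compound 2 are built from the same atoms joined differently; the difference between the two cores is not broken down here. Compound 2 gives the lowest of the three numbers, with compound 1 and compound 3 both above it by amounts beyond the scatter.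

For the measured compounds named here, the one change measured is fluoro in place of methyl on an aromatic carbon, which gave a number 4.2 percentage points higher from compound 1 to compound 3 (within the scatter).

Compound 4, `CC(=O)c1ccc(OCc2cccc(F)c2)cc1`, is not yet measured. It differs from compound 2 by fluoro in place of methyl on an aromatic carbon. This is the same kind of change as from compound 1 to compound 3, not the same one: there the place is "ortho to a large group", here it is "meta to a large group".

The step is expected to be a number 3.7 percentage points higher from compound 2 to compound 4 (within the scatter), small because a number 4.2 percentage points higher from compound 1 to compound 3 (within the scatter) lay within the scatter. Compound 4 is estimated at 36% in this assay, with a likely range from 22% to 50%.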

Compound 4, a percentage reported as inhibition, at one concentration (the size of the read-out at that concentration, not a potency): 48.4%
Compound 4: middle estimate off by 12.4 percentage points, on the low side, and the stated range covers the measured number.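

In this assay, fluoro in place of methyl on an aromatic carbon, meta to a large group, gives a number 16.1 percentage points higher from compound 2 to compound 4 (beyond the scatter). Set beside the same change on the other core, ortho to a large group, this step cannot be told apart from the earlier one: the same change on two cores in this assay, a number 4.2 percentage points higher (within the scatter) from compound 1 to compound 3 and a number 16.1 percentage points higher (beyond the scatter) from compound 2 to compound 4, 11.9 percentage points apart, within the scatter of two such steps

So the two cores give no firm sign that the change behaves differently from one to the other, but this does not show that the step has one fixed size, that its place on the ring governs its size, or that two pairs make a rule for the series.

Left open is whether chloro, methoxy, nitrile or an amine at these two places would give numbers like those of fluoro or methyl. Also open, on these data alone, is whether the change carries over when the carbonyl end of the shared core gives way to an amide or a carboxylic acid, and how any of this reads as a potency rather than as a reading at one concentration.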